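Cytotoxicity in the benzamide acid series: indole variant

A few compounds are considered here, and "the series" means these few. Any claim that something is new, unique, unknown or untested is made for them only; others in the source may bear on it.

The shared core carries an isopropyl amide, a benzyl group bearing a hexanoic acid ether chain, and a varying aryl group on the benzamide. Compound 1 `CC(=O)c1cccc(-c2ccc(C(=O)N(Cc3cccc(OCCCCCC(=O)O)c3)C(C)C)cc2)c1` was tested in an ADME assay on Raji cells (Homo sapiens) for cytotoxicity, read by CellTiter-Glo and resazurin assay, with a stated time of 72 h; on this read-out higher numbers stand for an effect only at larger amounts of compound and lower numbers for an effect already at smaller amounts; compound 1 gives > 26000 nM, which is a limit of the assay and not a number. Compound 2 `CC(C)N(Cc1cccc(OCCCCCC(=O)O)c1)C(=O)c1ccc(-c2ccco2)cc1` gives > 26000 nM in this assay, again a limit. Compound 3 `COc1cccc(-c2ccc(C(=O)N(Cc3cccc(OCCCCCC(=O)O)c3)C(C)C)cc2)c1` gives > 20900 nM in this assay, also a limit. All three values are therefore limits, two at the limit of > 26000 nM in this assay, at which 2 of the 3 values shown sit, and one at the limit of > 20900 nM in this assay, at which 1 of the 3 values shown sits, so the steps a step that the two limits leave unreadable from compound 1 to compound 2, a step that the two limits leave unreadable from compound 1 to compound 3 and a step that the two limits leave unreadable from compound 2 to compound 3 are unreadable in size; compound 3 thus stands only at a limit, level with the others as far as can be told.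

Compound 4 `CC(C)N(Cc1cccc(OCCCCCC(=O)O)c1)C(=O)c1ccc(-c2ccc3[nH]ccc3c2)cc1` differs from compound 3 by 1H-indol-5-yl in place of 3-methoxyphenyl on an aromatic carbon. Among the compounds with values here, no measured step bears readably on this change, and every measured aryl variant sits at a limit. For compound 4 the expectation in this assay is therefore a further limit rather than a number, with an estimated step that the limit leaves unreadable from compound 3 to compound 4 from compound 3. Compound 4 is estimated at 26000 nM, within 10000 nM to 60000 nM.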

Compound 4, half-maximal effective concentration: > 26000 nM
Compound 4: only a limit was reported; the forecaster's own chance of this, stated with the estimate: 85%; the middle value sits exactly at the limit.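

In this assay compound 4 gives > 26000 nM, a limit of the assay and not a number. Its steps with compound 1, compound 2 and compound 3 cannot be read. The compounds shown leave open whether the aryl group changes the read-out at all.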